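Two Small Alkyl Steps, One Still Unmeasured

This account rests on a few compounds, and the source may have more. Where it says the series, first, only, none or still open, it means among the compounds named here.

Compound 1, `CCc1ccc(Nc2ccc3c(c2)C(=O)N(C2CCC(=O)NC2=O)C3=O)cc1`, in an assay on FRT-Jurkat cells for inhibition of nuclear factor NF-kappa-B complex (Homo sapiens), read by flow cytometry, with a stated time of 24 h, tested at 10 uM (on this read-out lower numbers stand for less inhibition and higher numbers for more inhibition at the one concentration tested (going by the name of the read-out)), gives 5%.
Compound 2, `CC(C)c1ccc(Nc2ccc3c(c2)C(=O)N(C2CCC(=O)NC2=O)C3=O)cc1`, gives 11%.
Compound 3, `CCc1ccc(Nc2cccc3c2C(=O)N(C2CCC(=O)NC2=O)C3=O)cc1`, gives 17%.

Compound 1 and compound 2 share one core and differ by methyl in place of hydrogen on a saturated chain carbon bound to an aromatic carbon and a saturated chain carbon. That change produced a number 6 percentage points higher from compound 1 to compound 2 (within the scatter). Compound 3 has the same atoms as compound 1, joined differently; the difference between the two cores is not broken down here. Compound 3 carries the highest of the three numbers, beyond the scatter from compound 1 but within the scatter of compound 2.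

Compound 4, `CCCc1ccc(Nc2cccc3c2C(=O)N(C2CCC(=O)NC2=O)C3=O)cc1`, differs from compound 3 by methyl in place of hydrogen on a saturated chain carbon, two bonds along the chain from an aromatic carbon. Within the data shown here, this is the same kind of change as the one separating compound 1 and compound 2, though the surroundings differ: in compound 2 the methyl enters on a saturated chain carbon bound to an aromatic carbon and a saturated chain carbon, while in compound 4 it enters on a saturated chain carbon, two bonds along the chain from an aromatic carbon. Because the earlier step was a number 6 percentage points higher from compound 1 to compound 2 (within the scatter), a comparable small move is expected here. Compound 4 is expected to shift by a number 4 percentage points higher from compound 3 to compound 4 (within the scatter). Compound 4 is therefore estimated at 21%, between 8% and 36%.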

Compound 4, a percentage reported as inhibition, at one concentration (the size of the read-out at that concentration, not a potency): 23%
The estimate for compound 4 lay 2 percentage points below the measured number, within the range that was stated.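

On the core of compound 3, methyl in place of hydrogen on a saturated chain carbon, two bonds along the chain from an aromatic carbon, gave a number 6 percentage points higher from compound 3 to compound 4 (within the scatter) in this assay. Set beside the earlier step, the change carried from one core to the other with no difference that can be told apart: the same change on two cores in this assay, a number 6 percentage points higher (within the scatter) from compound 1 to compound 2 and a number 6 percentage points higher (within the scatter) from compound 3 to compound 4, 0 percentage points apart, within the scatter of two such steps This does not show that the added methyl raises inhibition on either core, as each step taken alone lies within the scatter, and the methyl enters on a different chain carbon in each pair, so the two steps are close parallels and not an exact repeat.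

The compounds shown leave open how a longer chain, such as butyl, would read on either core. They also leave open what an amine or a carboxylic acid in place of the alkyl chain would give in this assay.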